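Pyrrolidine nitrogen substituent variation on the shared core

A few compounds are considered here, and "the series" means these few. Any claim that something is new, unique, unknown or untested is made for them only; others in the source may bear on it.

In a functional assay on HCC827 cells (Homo sapiens) for antiproliferative activity, read by MTT assay, with a stated time of 72 h (a lower number here means a stronger inhibitor, a higher number a weaker inhibitor), compound 1 `CN1CCN(c2ccc(Nc3ncc4nc(Nc5ccccc5)n([C@H]5CCNC5)c4n3)cc2)CC1` gives 530 nM, compound 2 `CN1CCN(c2ccc(Nc3ncc4nc(Nc5ccccc5)n([C@@H]5CCN(S(=O)(=O)C6CC6)C5)c4n3)cc2)CC1` gives 0.88 nM, and compound 3 `CC(=O)N1CC[C@H](n2c(Nc3ccccc3)nc3cnc(Nc4ccc(N5CCN(C)CC5)cc4)nc32)C1` gives 260 nM. Compound 3 thus has the second highest number of the three: its nearest neighbour is compound 1, from which it is separated by a 2.0-fold lower number from compound 1 to compound 3 (0.31 log units; beyond the scatter), while the largest gap is a 300-fold higher number from compound 2 to compound 3 (2.47 log units; beyond the scatter). Compound 4 `CNC(=O)CN1CC[C@H](n2c(Nc3ccccc3)nc3cnc(Nc4ccc(N5CCN(C)CC5)cc4)nc32)C1` differs from compound 3 by (methylcarbamoyl)methyl in place of acetyl on an amine nitrogen in a ring. Going by the values given here, two measured steps bear on this position: the acetyl substitution in this assay gave a 2.0-fold lower number from compound 1 to compound 3 (0.31 log units; beyond the scatter), whereas the sulfonyl gave a 600-fold lower number from compound 1 to compound 2 (2.78 log units; beyond the scatter). Among the compounds with values here, no measured step covers an alkyl amide on this nitrogen, so the direction is open; the modest acetyl gain and the large sulfonyl gain argue against a loss, but nothing supports a step of the sulfonyl size. The expected outcome for compound 4 is therefore a 1.3-fold lower number from compound 3 to compound 4 (0.11 log units; within the scatter), within the scatter. Compound 4 is estimated at 200 nM, in the range 40 nM to 1000 nM.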

Compound 4, half-maximal inhibitory concentration: 170 nM
Compound 4: middle estimate off by 1.2-fold (0.07 log units), on the high side; the measured number falls inside the stated range.
By their numbers in this assay, from the lowest: compound 2; then compounds 4 and 3 (each within the scatter of the next); then compound 1.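

Placing (methylcarbamoyl)methyl in place of acetyl on the amine nitrogen in the ring adds a hydrogen-bond donor, yet in this assay the two compounds cannot be told apart (a 1.5-fold lower number from compound 3 to compound 4 (0.18 log units; within the scatter)). Relative to hydrogen on this nitrogen, the change remains modest (a 3.1-fold lower number from compound 1 to compound 4 (0.49 log units; beyond the scatter)), whereas the gap to the sulfonyl compound remains large (a 190-fold higher number from compound 2 to compound 4 (2.29 log units; beyond the scatter)), so among these four compounds only 1-(cyclopropylsulfonyl)pyrrolidin-3-yl gives a large step. No measurement shown here explains these differences.

Still open, from the compounds shown here alone, is whether the sulfonyl or its cyclopropyl part accounts for that step, which methylsulfonyl and cyclopropylcarbonyl on this nitrogen would help separate. Also open, going by these compounds, is how a carboxylic acid in place of the methylamide end of the chain would read in this assay.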